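The source may hold more compounds than are shown below. What is called first, only, known or untested is meant among the compounds shown, and "the series" means these compounds.

Among the compounds with values here, compound 1 `N#CC1=C(N)Oc2c(c3nc4ccccc4nc3c3ccccc23)C12C(=O)N(Cc1cnnn1-c1ccc(Br)cc1)c1ccccc12` is the only compound here with a measured number: in a functional assay on A549 cells (Homo sapiens) for antiproliferative activity, read by MTT assay, with a stated time of 48 h (a higher number here means a weaker inhibitor, a lower number a stronger inhibitor), compound 1 gives 44300 nM. Compound 2 `N#CC1=C(N)Oc2c(c3nc4ccccc4nc3c3ccccc23)C12C(=O)N(Cc1cnnn1-c1ccccc1Br)c1ccccc12` reaches only a limit of the assay, giving > 50000 nM in this assay. Compound 3 `COc1ccccc1-n1nncc1CN1C(=O)C2(C(C#N)=C(N)Oc3c2c2nc4ccccc4nc2c2ccccc32)c2ccccc21` likewise reaches only a limit, giving > 50000 nM. The step from compound 1 to compound 2 is an at least 1.1-fold higher number from compound 1 to compound 2 (0.05 log units; that floor lies within the scatter), and the step from compound 1 to compound 3 is an at least 1.1-fold higher number from compound 1 to compound 3 (0.05 log units; that floor lies within the scatter); both end at the limit of > 50000 nM in this assay, at which 2 of the 3 values shown sit. Compound 4 `Cc1cc(C)cc(-n2nncc2CN2C(=O)C3(C(C#N)=C(N)Oc4c3c3nc5ccccc5nc3c3ccccc43)c3ccccc32)c1` is not yet measured. It differs from compound 1 in one place: 3,5-dimethylphenyl in place of 4-bromophenyl on an aromatic nitrogen. The two measured exchanges of the 4-bromophenyl group on that aromatic nitrogen, to 2-bromophenyl and to 2-methoxyphenyl, each ended at the limit rather than at a number. An exchange to 3,5-dimethylphenyl is therefore expected to give a weak result as well, with a fair chance that only a limit is reported again. Compound 4 is estimated at 60000 nM, between 30000 nM and 150000 nM, which means an expected step of a 1.4-fold higher number from compound 1 to compound 4 (0.13 log units; within the scatter).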

Compound 4, half-maximal inhibitory concentration: > 50000 nM
Compound 4: only a limit was reported; the forecaster's own chance of this, stated with the estimate: 55%; the middle value lies beyond the limit too.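

Compound 4 shows that a phenyl ring carrying two methyl groups, with neither bromine nor methoxy, also gives no number in this assay, only a limit of the assay. The step is an at least 1.1-fold higher number from compound 1 to compound 4 (0.05 log units; that floor lies within the scatter), so 3,5-dimethylphenyl cannot be called weaker than 4-bromophenyl; it only fails to bring the compound into the measurable range. The steps linking compound 4 to compound 2 and compound 3 join two limits and cannot be read, and compound 1 remains the one exception to this run of results: the limit of > 50000 nM in this assay, at which 3 of the 4 values shown sit.

The compounds shown leave open whether any group on that aromatic nitrogen can give a clearly lower number than compound 1. A plain phenyl ring, or a phenyl ring carrying an amine or a carboxylic acid, would test this.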